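Amide series: ester-bearing amine replaces aminophenyl on core

The source may report more compounds than this note shows. Statements on the series, on what has been measured and on what is new or still open speak of the compounds shown alone.

Working notes on the series. Among the measured compounds shown here, compound 1 `Nc1ccc(Nc2c(C(=O)NCc3ccc(F)cc3)nc(Br)c3cccnc23)cc1` is the only member with a number: in a functional assay on HCT-116 cells (Homo sapiens) for cytotoxicity, read by MTT assay, with a stated time of 72 h (a higher number here means a weaker inhibitor, a lower number a stronger inhibitor), compound 1 gives 7000 nM, which makes it the sole reference point and, by that number, a weak inhibitor. Compound 2 `C[C@H](CO)Nc1nc(C(=O)NCc2ccc(F)cc2)c(O)c2ncccc12` belongs to the same series but in this assay compound 2 is recorded as "not determined" (no result reported), so it offers no point of comparison. For the measured compounds named here, no step between two measured compounds can therefore be drawn.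

Compound 3 `COC(=O)CNc1c(C(=O)NCc2ccc(F)cc2)nc(Br)c2cccnc12` is the next entry to be run in this assay. It differs from compound 1 in one place: (methoxycarbonyl)methyl in place of 4-aminophenyl on a nitrogen on an aromatic ring. The shared core and the rest of the amide side are unchanged.

Going by the values given here, with no measured step to lean on, the expectation rests on the weak standing of compound 1 alone: the expected step is none beyond the scatter, leaning a little toward weaker, estimated as a 1.3-fold higher number from compound 1 to compound 3 (0.11 log units; within the scatter). Compound 3 is estimated at 9000 nM in this assay, with a range from 2500 nM to 30000 nM. Because compound 1 already sits at 7000 nM, a weak result is the expectation for compound 3 as well.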

Compound 3, half-maximal inhibitory concentration: > 10000 nM
Compound 3 gave a limit, no number (the forecaster's own chance of this, stated with the estimate: 25%); at least 1.1-fold (0.04 log units) between middle value and limit.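

For compound 3, the reading in this assay is a limit of the assay and not a number: the limit of > 10000 nM in this assay, at which 1 of the 3 values shown sits.

Among the compounds shown here, the change at this position, on a nitrogen on an aromatic ring, gives an at least 1.4-fold higher number from compound 1 to compound 3 (0.15 log units; that floor lies within the scatter), and this is the first measured comparison. It gives no sign that (methoxycarbonyl)methyl yields a stronger inhibitor than 4-aminophenyl, although a floor of this size cannot show that compound 3 is truly weaker than compound 1.

The compounds shown leave open the true value of compound 3 and whether any group on this nitrogen can give a stronger inhibitor than compound 1. A plain phenyl would test the ring without its amine, while the carboxylic acid matching the methyl ester or a longer chain carrying the same ester would show whether the outcome follows the ester or the length of the group.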